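A few compounds are considered here, and "the series" means these few. Any claim that something is new, unique, unknown or untested is made for them only; others in the source may bear on it.

For the measured compounds named here, compound 1 `CC(C)NCC(=O)NCC(=O)N(C)c1ccc(Cl)cc1C(=O)c1ccccc1Cl` gives 13 mg/kg in a functional assay on the whole organism with Mus musculus as the target, in the rotarod test (a higher number here means that more compound is needed for the effect, a lower number that less compound is needed), and this is the only actual number so far. Compound 2 `NC(C(=O)NCC(=O)Nc1ccc(Cl)cc1C(=O)c1ccccc1)c1ccccc1` is recorded at > 100 mg/kg, which is a limit of the assay and not a number. Compound 1 therefore stands on the side of less compound needed, with no second number to rank it against.

Compound 3 `CN(C(=O)CNC(=O)c1ccccc1)c1ccc(Cl)cc1C(=O)c1ccccc1Cl` keeps the core of compound 1 and carries phenyl in place of (isopropylamino)methyl on a carbonyl carbon. Cut one bond further out, the same change reads ((isopropylamino)methyl)carbonyl to benzoyl. Going by the values given here, no measured pair isolates this change, so any expectation for it remains a judgement with a wide margin.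

In this assay, a move towards more compound needed is expected, beyond the usual scatter, and a result reported only as a limit would be no surprise. The expected size of the step of a 5.4-fold higher number from compound 1 to compound 3 (0.73 log units; beyond the scatter) rests on compound 1 at 13 mg/kg as the sole numerical anchor. For compound 3 the estimated value is 70 mg/kg, with an expected range from 25 mg/kg to 200 mg/kg.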

Compound 3, dose for half-maximal effect: > 100 mg/kg
Compound 3: a limit, no number (the forecaster's own chance of this, stated with the estimate: 45%); middle value at least 1.4-fold (0.15 log units) from the limit.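

In this assay compound 3 is recorded at > 100 mg/kg as a limit of the assay and not a number. The series now has its first readable step, an at least 7.6-fold higher number from compound 1 to compound 3 (0.88 log units; beyond the scatter), and it shows that on this carbonyl carbon, with an amide-type nitrogen as its other neighbour, phenyl in place of (isopropylamino)methyl goes with more compound being needed, by a margin that clears the usual scatter. Going by these compounds, the true size of the step stays open at its upper end because the read-out stops at a limit for this compound: the limit of > 100 mg/kg in this assay, at which 2 of the 3 values shown sit.

This single change removes a chain with a nitrogen and no ring and brings in an all-carbon aromatic ring, so the result cannot tell whether the nitrogen, the ring or both matter at this position. A cyclohexyl group or a plain aminomethyl group on the same carbonyl carbon would separate those two parts of the change, and a longer aminoalkyl chain would test whether the distance of the nitrogen from the carbonyl counts.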